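A few compounds are considered here, and "the series" means these few. Any claim that something is new, unique, unknown or untested is made for them only; others in the source may bear on it.

Compound 1 `CCOC(=O)C1=Cc2ccccc2OC1(OCc1cn(-c2cccc(OC)c2)nn1)C(F)(F)F` belongs to a small set run in a functional assay on MCF7 cells (Homo sapiens) for inhibition, read by MTT assay, with a stated time of 24 h; a lower number here means a stronger inhibitor, a higher number a weaker inhibitor. In this assay compound 1 gives only a limit, > 150000 nM, and no number. Compound 1 thus stands at the limit of > 150000 nM in this assay, at which 1 of the 3 values shown sits. Compound 2 `CCOC(=O)C1=Cc2ccccc2OC1(OCc1cc(-c2ccc3ccccc3c2)no1)C(F)(F)F` gives 65400 nM, and compound 3 `O=C(O)C1=Cc2ccccc2OC1(OCc1cc(-c2ccc(F)cc2)no1)C(F)(F)F` gives 64200 nM; these two lie within the scatter of each other. Compound 4 `CCOC(=O)C1=Cc2ccccc2OC1(OCc1cn(CC(=O)Nc2ccccc2F)nn1)C(F)(F)F` is not yet measured. It differs from compound 1 in one place: ((2-fluorophenyl)carbamoyl)methyl in place of 3-methoxyphenyl on an aromatic nitrogen. For the measured compounds named here, no measured pair shows this change, so no step size can be read from the data; a move of about the scatter, in either direction, is expected at most. Compound 4 is expected to give 100000 nM, between 30000 nM and 300000 nM. This estimate means a step of an at least 1.5-fold lower number from compound 1 to compound 4 (0.17 log units; that floor lies within the scatter), with a fair chance that only a limit is reported again.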

Compound 4, half-maximal inhibitory concentration: 42100 nM
Beside the measured number, compound 4's estimate is 2.4-fold (0.38 log units) above it; the range from low to high includes it.
By their numbers in this assay, from the lowest: compounds 4, 3 and 2 (each within the scatter of the next). At a limit, above all of these: compound 1.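

On the aromatic nitrogen of the five-membered ring with 3 nitrogen, the group can move the read-out in this assay: ((2-fluorophenyl)carbamoyl)methyl in place of 3-methoxyphenyl gives an at least 3.5-fold lower number from compound 1 to compound 4 (0.55 log units; beyond the scatter). This is the only step in the series that can be read, and it is a floor, as compound 1 gives only a limit: the limit of > 150000 nM in this assay, at which 1 of the 4 values shown sits.

Which part of the entering group carries the step stays open: the carbonyl, the amide hydrogen, the fluorine or the methylene link. Also open, as far as these compounds go, is how a longer chain or a terminal amine on that nitrogen would read.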